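The source may hold more compounds than are shown below. What is called first, only, known or untested is meant among the compounds shown, and "the series" means these compounds.

Compound 1 `Cc1ccc(-c2ccc(NCc3ccccc3O)cc2)cc1` is the reference point of this series. In a functional assay on Jurkat cells (Homo sapiens) for activation, with a stated time of 24 h (a higher number here means that more compound is needed for the effect, a lower number that less compound is needed), compound 1 gives 3790 nM, the lowest of the three numbers measured, though its neighbours sit close by. Compound 2 `Oc1ccccc1CNc1ccc(-c2cccc(Cl)c2)cc1` gives 6200 nM in this assay, and compound 3 `Cc1ccccc1-c1ccc(NCc2ccccc2O)cc1` gives 5220 nM. The steps among them are small: a 1.6-fold higher number from compound 1 to compound 2 (0.21 log units; within the scatter), a 1.4-fold higher number from compound 1 to compound 3 (0.14 log units; within the scatter) and a 1.2-fold lower number from compound 2 to compound 3 (0.07 log units; within the scatter), each within the scatter, so none of the three can be set apart from the others.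

Compound 4 `CCCOc1ccc(-c2ccc(NCc3ccccc3O)cc2)cc1` has not yet been measured. It differs from compound 1 in one place: propoxy in place of methyl on an aromatic carbon. Going by the values given here, no measured step changes this position in the same way; the three known steps only swap one substituent on the outer aromatic ring for another, and all of them stay within the scatter. What they show is that changes at that ring have so far moved the number little, but none of them introduces a propoxy group or any group with a hydrogen-bond acceptor, so they give no direct guide.

On that basis the expectation for compound 4 in this assay is a step of a 1.1-fold lower number from compound 1 to compound 4 (0.03 log units; within the scatter), that is, essentially no change beyond the scatter, with an estimated value of 3500 nM and a range from 1400 nM to 9000 nM.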

Compound 4, half-maximal effective concentration: "not active" (no number reported)
Nothing numeric was reported for compound 4; the estimate stays without a comparison.
By their numbers in this assay, from the lowest: compounds 1, 3 and 2 (each within the scatter of the next).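

In this assay, going by these compounds alone, compound 4 gives "not active" (no number reported), so no step from compound 1 to compound 4 can be read. Nothing shown here offers an explanation for this result. The compounds shown leave open whether compound 4 would give a number at any concentration, and how propoxy in place of methyl compares with compound 1.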